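Amide-nitrogen variation in a Toll-like receptor 2 agonist series

This account rests on a few compounds, and the source may have more. Where it says the series, first, only, none or still open, it means among the compounds named here.

Measured compounds:
compound 1 `CCCCCCCCCCCC(=O)OC[C@H](CSC[C@@H](N)C(=O)NC(C)CCc1ccccc1)OC(=O)CCCCCCCCCCC`: 160 nM
compound 2 `CCCCCCCCCCCC(=O)OC[C@H](CSC[C@@H](N)C(=O)NC(CC)COC)OC(=O)CCCCCCCCCCC`: 71.8 nM
compound 3 `CCCCCCCCCCCC(=O)OC[C@H](CSC[C@@H](N)C(=O)NCCN)OC(=O)CCCCCCCCCCC`: 5240 nM

In an assay on HEK293 cells for agonist activity at Toll-like receptor 2 (Homo sapiens) (on this read-out lower numbers stand for an effect already at smaller amounts and higher numbers for an effect only at larger amounts of compound), compound 3 stands highest of the three numbers; its nearest neighbour is compound 1 and its furthest is compound 2, both well beyond the scatter. The measured steps onto compound 3 are a 33-fold higher number from compound 1 to compound 3 (1.52 log units; beyond the scatter) and a 73-fold higher number from compound 2 to compound 3 (1.86 log units; beyond the scatter); between the two branched substituents the step is a 2.2-fold lower number from compound 1 to compound 2 (0.35 log units; beyond the scatter), a modest one.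

Compound 4 `CCCCCCCCCCCC(=O)OC[C@H](CSC[C@@H](N)C(=O)NC(C)CCN(CC)CC)OC(=O)CCCCCCCCCCC` is not yet measured. It differs from compound 3 by 3-(diethylamino)-1-methylpropyl in place of 2-aminoethyl on an amide-type nitrogen. Among the measured compounds shown here, the change runs from the only 2-aminoethyl compound back toward the kind of substitution seen in compounds 1 and 2, which both carry a branched group with a methyl at the carbon joined to the amide nitrogen, and both sit far below compound 3. Both large steps onto compound 3 therefore bear on this change, in reverse; how far the diethylamino end reshapes the outcome cannot be read from the three compounds shown, so the expected step is placed between the two known ones with a wide range.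

For compound 4 the expected step is a 17-fold lower number from compound 3 to compound 4 (1.24 log units; beyond the scatter), giving an estimate of 300 nM in this assay, with a range from 60 nM to 2000 nM.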

Compound 4, half-maximal effective concentration: 257 nM
Compound 4: middle estimate off by 1.2-fold (0.07 log units), on the high side; the range from low to high includes it.
By their numbers in this assay, from the lowest: compound 2; then compounds 1 and 4 (each within the scatter of the next); then compound 3.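

In this assay, 3-(diethylamino)-1-methylpropyl in place of 2-aminoethyl on the amide-type nitrogen gives a 20-fold lower number from compound 3 to compound 4 (1.31 log units; beyond the scatter) and so shows that an amine nitrogen in this substituent does not on its own go with the high number of compound 3. Diethylamino in place of phenyl on the saturated chain carbon gives a 1.6-fold higher number from compound 1 to compound 4 (0.21 log units; within the scatter) and leaves compound 1 and compound 4 indistinguishable at this position, so this site accepts both an aryl-ended and an amine-ended substituent on the same branched chain. The step to the 1-(methoxymethyl)propyl analogue remains measurable, at a 3.6-fold higher number from compound 2 to compound 4 (0.55 log units; beyond the scatter) in a modest step.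

The change from compound 3 to compound 4 alters the chain length, the methyl branch and the substitution on the amine together, and a 2-(diethylamino)ethyl group or a 3-amino-1-methylpropyl group would be needed to separate these parts. No measurement is available that explains any of these steps.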